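Pyridyl amidrazone thiosemicarbazides: methyl removal on the pyridine ring

The compounds below may be only part of what the source reports. "The series", "measured", "known", "first", "only" and "open" are said of these compounds alone.

Measured compounds in a functional assay on HeLa cells (Homo sapiens) for cytotoxicity, read by MTT assay, with a stated time of 72 h, tested at 10 uM; on this read-out lower numbers stand for less inhibition of growth and higher numbers for more inhibition of growth at the one concentration tested:
compound 1 `Cc1ccnc(/C(N)=N/NC(=S)N2CCN(c3ccccn3)CC2)c1`: 49.2%
compound 2 `N/C(=N\NC(=S)N1CCCCC1)c1ccccn1`: 55.7%
compound 3 `Cc1ccnc(/C(N)=N/NC(=S)N2CCCCC2)c1`: 62.1%

Compound 2 and compound 3 share a core and differ in one place, (hydrogen in place of methyl on an aromatic carbon). The step that this change made is a number 6.4 percentage points lower from compound 3 to compound 2 (within the scatter), so compound 2 and compound 3 cannot be told apart on this read-out. Compound 1 differs from compound 3 in more than one place; the difference between the two cores is not broken down here. Compound 1 gives the lowest of the three numbers; its gap to compound 2 is within the scatter, its gap to compound 3 beyond it.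

Compound 4 `N/C(=N\NC(=S)N1CCN(c2ccccn2)CC1)c1ccccn1` is not yet measured. It stands to compound 1 as compound 2 stands to compound 3: hydrogen in place of methyl on an aromatic carbon. Within the data shown here, the place of the change is the same in both pairs, so it is the same change, and the only measured example of it is the step from compound 3 to compound 2. On these data alone, on that basis the step from compound 1 to compound 4 is expected to be a number 6.2 percentage points lower from compound 1 to compound 4 (within the scatter), a small step resting on a single precedent, and compound 4 is estimated at 43% in this assay, with a range expected from 30% to 56% because the precedent a number 6.4 percentage points lower from compound 3 to compound 2 (within the scatter) is itself within the scatter and the transfer from one core to the other is untested.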

Compound 4, percent growth inhibition at one concentration: 56.1%
Estimate against measurement, compound 4: 13.1 percentage points below; the measured number lies above the stated range.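

In this assay, the exchange of 4-methylpyridin-2-yl for pyridin-2-yl on the second core gives a step of a number 6.9 percentage points higher from compound 1 to compound 4 (within the scatter), so this pair cannot be told apart on this read-out. Set beside the earlier pair, the two steps carry opposite signs, but neither sign can be read as real, and the gap between them gives no ground for saying that the core changes the outcome: the same change on two cores in this assay, a number 6.4 percentage points lower (within the scatter) from compound 3 to compound 2 and a number 6.9 percentage points higher (within the scatter) from compound 1 to compound 4, 13.3 percentage points apart, within the scatter of two such steps. This shows that, on both cores, the effect of the change on growth inhibition at the one concentration tested is too small to resolve; it does not show that the change is without effect, that its effect is the same on both cores, or that its effect differs between them, and two pairs cannot establish a rule for carrying it to further cores.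

The compounds shown hold only methyl or hydrogen at this place on the pyridine ring, so it remains open whether a methoxy group, a chlorine atom, an amine or a longer alkyl chain there would give a step beyond the scatter. Also open, on these data alone, is whether either pair would separate in a full concentration-response read-out rather than at the single concentration used here.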